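The compounds below may be only part of what the source reports. "The series", "measured", "known", "first", "only" and "open" are said of these compounds alone.

Working notes on the series. In an ADME assay on Caco-2 cells (Homo sapiens) for permeability, in the apical to basolateral direction (on this read-out lower numbers stand for lower permeability and higher numbers for higher permeability), compound 1 (`CC(=O)N1CCN(c2cccc(-c3ccc4c(N)ncnn34)c2)C(=O)C1(C)C`) stands at "not determined" (no result reported) and offers no number to start from. For the measured compounds named here, compound 2 (`CC(=O)N1CCN(c2cccc(-c3cc(-c4ccnn4C4CC4)c4c(N)ncnn34)c2)C(=O)C1(C)C`) gives 36 nm/s in this assay and holds the only plain number. Compound 3 (`CC(=O)N1CCN(c2cccc(-c3cc(-c4cnc(Cl)n4C)c4c(N)ncnn34)c2)C(=O)C1(C)C`) gives < 36 nm/s as a limit of the assay and not a number. Going by the values given here, the one measured step runs a number no higher from compound 2 to compound 3 (the limit leaves the size open) and ends on the limit of < 36 nm/s in this assay, at which 1 of the 3 values shown sits, so it gives no size to carry forward.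

Compound 4 (`CC(=O)N1CCN(c2cccc(-c3cc(C#N)c4c(N)ncnn34)c2)C(=O)C1(C)C`) carries cyano in place of hydrogen on an aromatic carbon of the core of compound 1 (cyano in place of hydrogen on an aromatic carbon). Among the compounds with values here, the measured step exchanges 1-cyclopropyl-1H-pyrazol-5-yl for 2-chloro-1-methyl-1H-imidazol-5-yl, and no measured pair involves cyano. With no number for compound 1, no size or direction can be expected for this change in this assay. The expectation therefore rests loosely on compound 2 (36 nm/s) and stays wide. For compound 4 a report of only a limit would not surprise. For compound 4 the expected value is 40 nm/s with an estimated range from 14 nm/s to 115 nm/s in this read-out.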

Compound 4, apparent permeability: 84 nm/s
For compound 4 the middle estimate is 2.1-fold (0.32 log units) below the measured one; low and high end bracket the measured number.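

For the compounds shown here, at the aromatic carbon two ring bonds from the ring nitrogen, this assay now gives a first step of readable size: a 2.3-fold higher number from compound 2 to compound 4 (0.37 log units; beyond the scatter), with cyano replacing 1-cyclopropyl-1H-pyrazol-5-yl. Replacing 2-chloro-1-methyl-1H-imidazol-5-yl with cyano at the same carbon gives an at least 2.3-fold higher number from compound 3 to compound 4 (0.36 log units; beyond the scatter), but the value of compound 3 is a limit of the assay, so this step has a lower bound and no exact size: the limit of < 36 nm/s in this assay, at which 1 of the 4 values shown sits. Going by these compounds alone, both steps are printed as beyond the scatter and point the same way, so among the three groups compared at this carbon, cyano, the only one with no ring, carries the highest number.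

Compound 1 offers no number, so the step from hydrogen to cyano cannot be read, and three groups cannot separate the absence of a ring from anything particular to cyano. As far as these compounds go, how an amine, a methyl group or a carboxylic acid at this carbon would read in this assay remains open, as does whether a ring other than these two would stay as low as compound 2.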